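The source may report more compounds than this note shows. Statements on the series, on what has been measured and on what is new or still open speak of the compounds shown alone.

Compound 1 `CCCCCN1C(=O)C/C(=C\c2cccc(C(=O)Nc3ccc(C)cc3)c2)C1=O`: in an ADME assay on HCT-116 cells (Homo sapiens) for cytotoxicity, read by MTT assay, with a stated time of 72 h (a higher number here means a weaker inhibitor, a lower number a stronger inhibitor), compound 1 gives > 100000 nM, a limit of the assay rather than a number.
Compound 2 `CCc1cccc(NC(=O)c2cccc(/C=C3\CC(=O)N(Cc4ccccc4)C3=O)c2)c1`: in this assay compound 2 gives 80600 nM.
Compound 3 `CCCCCN1C(=O)C/C(=C\c2cccc(C(=O)NCCCC)c2)C1=O`: in this assay compound 3 gives > 100000 nM, again a limit of the assay rather than a number.

Compound 3 therefore has no measured number in this assay, only a limit, and it shares that standing with compound 1 (the limit of > 100000 nM in this assay, at which 2 of the 3 values shown sit). The one step among these compounds, a step that the two limits leave unreadable from compound 1 to compound 3, cannot be read for size because both ends sit at the limit.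

Compound 4 `CCCCNC(=O)c1cccc(/C=C2\CC(=O)N(Cc3ccccc3)C2=O)c1` differs from compound 3 in one place: phenyl in place of butyl on a saturated chain carbon bound to an amide-type nitrogen in a ring. The same kind of substituent, a benzyl on the ring nitrogen, is present in compound 2, which pairs it with an aryl amide, whereas compound 4 keeps the butyl amide of compound 3; compound 1 and compound 2 differ in more than one place, so their values are shown only side by side. Among the measured compounds shown here, no measured step isolates the benzyl-for-pentyl change, so the expected size of a number no higher from compound 3 to compound 4 (the limit leaves the size open) is none that can be read beyond the scatter. Compound 4 is accordingly estimated at 100000 nM in this assay, within a range of 40000 nM to 300000 nM.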

Compound 4, half-maximal inhibitory concentration: 95100 nM
Estimate against measurement, compound 4: 1.1-fold (0.02 log units) above, and the stated range covers the measured number.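

Compound 4 gives the change from pentyl to benzyl its first readable bound, though a small one: an at least 1.0-fold lower number from compound 3 to compound 4 (0.02 log units; that floor lies within the scatter). Among the compounds shown here, that floor does not show how large the change really is, since one end of the step is a limit, but the benzyl compounds also allow the first readable comparison on the amide side, which the step between the two pentyl compounds could not give: a 1.2-fold higher number from compound 2 to compound 4 (0.07 log units; within the scatter). With benzyl held in place, butyl and 3-ethylphenyl on the amide-type nitrogen therefore cannot be told apart in this assay, and the series remains tied to the top of the measurable range: the limit of > 100000 nM in this assay, at which 2 of the 4 values shown sit.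

Still open, as far as these compounds go, is whether any group at either place can move the number clearly beyond the scatter, as the two benzyl compounds give values within the scatter of each other. An amine or a carboxylic acid on the phenyl of the benzyl group, or a longer chain on the amide-type nitrogen, would test this, and the compounds shown say nothing about how either would read.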